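Three Amides Without Cytotoxicity and a Methoxyphenyl Analogue

The compounds below may be only part of what the source reports. "The series", "measured", "known", "first", "only" and "open" are said of these compounds alone.

The series was tested in an ADME assay on HepG2 cells (Homo sapiens) for cytotoxicity, read by CellTiter-Glo and resazurin assay, with a stated time of 72 h; a lower number here means that less compound is needed, a higher number that more compound is needed for the effect. Compound 1 `CC(C)N(Cc1cccc(OCCCCCC(=O)O)c1)C(=O)c1ccc(-c2cc3ccccc3n2S(=O)(=O)c2ccccc2)cc1` gave only a limit of the assay, > 26000 nM. Compound 2 `CC(C)N(Cc1cccc(OCCCCCC(=O)O)c1)C(=O)c1ccc(-c2cccc(OC(F)(F)F)c2)cc1` likewise reached no number and stayed at the limit, > 26000 nM. Compound 3 `CCOC(=O)CCCCCOc1cccc(CN(C(=O)c2ccc(-c3ccc4ccccc4c3)cc2)C(C)C)c1` also sits at the limit in this assay, with > 26000 nM. So compound 3 stands nowhere above or below its neighbours: every value shown is a limit, (the limit of > 26000 nM in this assay, at which 3 of the 3 values shown sit), and no step between any two of the measured compounds can be read from these figures.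

Compound 4 `CCOC(=O)CCCCCOc1cccc(CN(C(=O)c2ccc(-c3cccc(OC)c3)cc2)C(C)C)c1` is the next member, not yet measured in this assay. It differs from compound 3 in a single place: 3-methoxyphenyl in place of naphthalen-2-yl on an aromatic carbon. Among the compounds with values here, with all three measured compounds resting at the same limit, there is no measured step to lean on for the direction of this change. The step expected for compound 4 is therefore a step that the limit leaves unreadable from compound 3 to compound 4, meaning no shift beyond the scatter that is expected. Compound 4 is estimated at 35000 nM, between 15000 nM and 90000 nM, and it is expected that this assay will once more report only a limit rather than a number.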

Compound 4, half-maximal effective concentration: > 21000 nM
Compound 4 gave a limit, no number; the forecaster's own chance of this, stated with the estimate: 80%; the middle value is on the limit's open side.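

In this assay compound 4 gave only a limit, > 21000 nM. Within the data shown here, compound 3 also carries only a limit, and no step between compound 3 and compound 4 can be read. The compounds shown leave open at what concentration, if any, they affect these cells, and whether 3-methoxyphenyl in place of naphthalen-2-yl changes that concentration.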